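Removing One Methyl Group at the Assay Limit

The compounds below may be only part of what the source reports. "The series", "measured", "known", "first", "only" and "open" are said of these compounds alone.

In a functional assay on MOLT-3 cells (Homo sapiens) for cytotoxicity, read by MTT assay, with a stated time of 48 h (a higher number here means a weaker inhibitor, a lower number a stronger inhibitor), compound 1 (`Cc1ccc(OCc2cn(-c3ccc(S(=O)(=O)N4CCc5ccccc5C4)cc3)nn2)cc1`) has no exact number, only a limit (> 50 ug/mL). Compound 2 (`COc1cc2c(cc1OC)CN(S(=O)(=O)c1ccc(-n3cc(COc4ccc([N+](=O)[O-])cc4)nn3)cc1)CC2`) likewise gives only a limit (> 50 ug/mL). The record so far is therefore the limit of > 50 ug/mL in this assay, at which 2 of the 2 values shown sit, and contains no exact value. Compound 3 (`O=S(=O)(c1ccc(-n2cc(COc3ccccc3)nn2)cc1)N1CCc2ccccc2C1`) is compound 1 with hydrogen in place of methyl on an aromatic carbon, turning 4-methylphenoxy into phenoxy (hydrogen in place of methyl on an aromatic carbon). Among the compounds with values here, no measured pair of compounds shows what this change does in this assay. With compound 1 reported only as a limit (> 50 ug/mL), no change beyond the usual scatter is expected. The estimated step that the limit leaves unreadable from compound 1 to compound 3 is accordingly expected to be small. Compound 3 is expected at about 60 ug/mL with an estimated range from 30 ug/mL to 120 ug/mL in this assay, and another limit is the likeliest report.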

Compound 3, half-maximal inhibitory concentration: > 50 ug/mL
Compound 3 gave a limit, no number; the forecaster's own chance of this, stated with the estimate: 85%; the middle value is on the limit's open side.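

Compound 1 and compound 3 are both reported only as limits, so the step between them, from methyl to hydrogen, cannot be read, and the record stands at one shared limit: the limit of > 50 ug/mL in this assay, at which 3 of the 3 values shown sit. The compounds shown leave open which structural change, if any, shifts cytotoxicity in this assay.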